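Hydrogen in place of fluoro on compound 3

The compounds below may be only part of what the source reports. "The series", "measured", "known", "first", "only" and "open" are said of these compounds alone.

In a functional assay on SW480 cells (Homo sapiens) for antiproliferative activity, read by MTT assay, with a stated time of 48 h (on this read-out lower numbers stand for stronger inhibition and higher numbers for weaker inhibition), compound 1 (`CCCC(CCO)n1cnc2c(Cl)nc(F)nc21`) gives 17200 nM, compound 2 (`CCCCCCCCC(CCO)n1cnc2c(Cl)nc(F)nc21`) gives 15000 nM and compound 3 (`CC(C)(C)[Si](C)(C)OCC(CCO)n1cnc2c(Cl)nc(F)nc21`) gives 8020 nM. Compound 3 separates from compound 1 only: a 2.1-fold lower number from compound 1 to compound 3 (0.33 log units; beyond the scatter) is modest but beyond the scatter, whereas a 1.9-fold lower number from compound 2 to compound 3 (0.27 log units; within the scatter) stays within it. The remaining pair shows no separation either, with a 1.1-fold lower number from compound 1 to compound 2 (0.06 log units; within the scatter) also within the scatter.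

Compound 4 (`CC(C)(C)[Si](C)(C)OCC(CCO)n1cnc2c(Cl)ncnc21`) departs from compound 3 by hydrogen in place of fluoro on an aromatic carbon. This is hydrogen in place of fluoro on an aromatic carbon, between two ring nitrogen atoms. All three measured compounds carry the fluoro group, and all three steps are changes on the saturated chain. Among the measured compounds shown here, no measured step therefore tests this aromatic carbon, and the data give no direction for the change. The steps bear on it only as a guide to size: the largest, a 2.1-fold lower number from compound 1 to compound 3 (0.33 log units; beyond the scatter), barely clears the scatter. On that limited basis, no step beyond the scatter is expected in this assay. The expected step is a 1.2-fold higher number from compound 3 to compound 4 (0.10 log units; within the scatter), an estimate with no firm direction. Compound 4 is estimated at 10000 nM, with an expected range from 4500 nM to 24000 nM.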

Compound 4, half-maximal inhibitory concentration: 31700 nM
Beside the measured number, compound 4's estimate is 3.2-fold (0.50 log units) below it; the whole stated range lies below it.
By their numbers in this assay, from the lowest: compounds 3, 2, 1 and 4 (each within the scatter of the next, the first and the last beyond it).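

In this assay, hydrogen in place of fluoro on the aromatic carbon between two ring nitrogen atoms gives a 4.0-fold higher number from compound 3 to compound 4 (0.60 log units; beyond the scatter), so this position is not silent and the fluoro group counts on the background of compound 3. This step is larger than any step on the saturated chain, the largest of which is a 2.1-fold lower number from compound 1 to compound 3 (0.33 log units; beyond the scatter), so in the compounds shown this aromatic carbon moves the number further than the chain changes do. No data on hand offer an explanation for the size or direction of the step.

Going by these compounds, the step rests on a single pair, with the chain of compound 3 as its only background, so whether the fluoro group counts to the same degree with the shorter chain of compound 1 or the longer chain of compound 2 stays open. Also open, on these data alone, is how an amine or a methoxy group on this aromatic carbon would compare with fluoro and hydrogen, and so whether the position responds to anything beyond this one exchange.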